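Benzoyl in place of 2-chlorobenzyl on the shared core

The source may report more compounds than this note shows. Statements on the series, on what has been measured and on what is new or still open speak of the compounds shown alone.

Three compounds sharing one core have been examined in an ADME assay on HEL cells (Homo sapiens) for cytotoxicity, with a stated time of 3 days; a higher number here means that more compound is tolerated, a lower number that less compound is tolerated. Compound 1 `CCC1(Cc2ccccc2)OS(=O)(=O)C=C1OCc1ccc(OC)cc1` gives >= 200000 nM, which is a limit of the assay rather than a number. Compound 2 `CCC1(Cc2ccccc2)OS(=O)(=O)C=C1OCc1ccccc1Cl` gives >= 20000 nM, again a limit. Compound 3 `CCC1(Cc2ccccc2)OS(=O)(=O)C=C1OCc1ccc([N+](=O)[O-])cc1` gives >= 80000 nM, also a limit. Because all three values are limits, the steps among them cannot be read: a step that the two limits leave unreadable from compound 1 to compound 2, a step that the two limits leave unreadable from compound 1 to compound 3 and a step that the two limits leave unreadable from compound 2 to compound 3. Compound 2 therefore stands at one of three limits, with no number of its own, and the other two values are limits as well.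

Compound 4 `CCC1(Cc2ccccc2)OS(=O)(=O)C=C1OC(=O)c1ccccc1` has not yet been measured in this assay. It differs from compound 2 in one place: benzoyl in place of 2-chlorobenzyl on an oxygen on an unsaturated carbon. Going by the values given here, no measured step bears on this change in a readable way, since each of the three steps is bounded by limits on both sides. Among the compounds with values here, no size of step in this assay can be expected from the data, in either direction, and a further limit is the most likely outcome. Compound 4 is nevertheless estimated at 80000 nM, with a range from 20000 nM to 320000 nM. This corresponds to an estimated step that the limit leaves unreadable from compound 2 to compound 4.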

Compound 4, minimum cytotoxic concentration: > 400000 nM
Compound 4 gave a limit, no number (the forecaster's own chance of this, stated with the estimate: 70%); middle value at least 5.0-fold (0.69 log units) away from the limit.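

In this assay compound 4 gives > 400000 nM, a limit and not a number. Compound 2 gives >= 20000 nM, also a limit. Going by these compounds alone, no step from compound 2 to compound 4 can therefore be read. The compounds shown leave open whether benzoyl in place of 2-chlorobenzyl changes the tolerated concentration at all.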